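A few compounds are considered here, and "the series" means these few. Any claim that something is new, unique, unknown or untested is made for them only; others in the source may bear on it.

Compound 1, `COC(=O)c1ccc(NCc2cncn2Cc2cccc(C)c2)cc1-c1ccccc1`, gives in a toxicity assay on NIH3T3 cells (Mus musculus) for cytotoxicity, read by resazurin assay (a higher number here means that more compound is needed for the effect, a lower number that less compound is needed), a value of > 10000 nM, a limit of the assay.
Compound 2, `COC(=O)c1ccc(NCc2cncn2Cc2ccc(-c3ccccc3)cc2)cc1-c1ccccc1`, gives > 1000 nM, likewise a limit of the assay.
Compound 3, `COC(=O)c1ccc(NCc2cncn2Cc2ccccc2F)cc1-c1ccccc1`, gives "not determined" (no result reported).

Within the data shown here, compound 2 thus stands only at a limit in this assay, and the two further entries of the set are one more limit and one entry without a number, so no compound of the set carries a single value. Among the measured compounds shown here, the one step among the measured compounds, a step that the two limits leave unreadable from compound 1 to compound 2, runs between two limits and its size cannot be read; it rests on the limit of > 10000 nM in this assay, at which 1 of the 3 values shown sits, and (the limit of > 1000 nM in this assay, at which 1 of the 3 values shown sits), which only bound the values from below.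

Compound 4, `Clc1ccc(NCc2cncn2Cc2ccc(-c3ccccc3)cc2)cc1-c1ccccc1`, differs from compound 2 by chloro in place of methoxycarbonyl on an aromatic carbon. For the measured compounds named here, no measured step touches this change, so the expectation for compound 4 rests on the fact that compound 2 sits at a limit in this assay and on the absence of any cytotoxic reading in the set. Compound 4 is therefore expected to show essentially no shift, a step that the limit leaves unreadable from compound 2 to compound 4, and to remain weakly toxic or again beyond the range of the assay. The estimate for compound 4 is 8000 nM, with a range from 2000 nM to 30000 nM.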

Compound 4, half-maximal effective concentration: > 1000 nM
Compound 4: no number, only a limit; the forecaster's own chance of this, stated with the estimate: 65%; the middle value is on the limit's open side.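

In this assay, compound 2 and compound 4 each stand only at a limit of the assay, so no size can be read for the change from methoxycarbonyl to chloro: the limit of > 1000 nM in this assay, at which 2 of the 4 values shown sit.

The compounds shown leave open at what concentration any of them becomes toxic to these cells, and whether this change shifts that concentration at all.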